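Swapping the Warhead: Chloroacetamide to Acrylamide on Compound 1

This account rests on a few compounds, and the source may have more. Where it says the series, first, only, none or still open, it means among the compounds named here.

Measured compounds:
compound 1 `O=C(CCl)Nc1ccc(Cn2nc(-c3ccc(Oc4ccccc4)cc3)cc2CO)cc1` – 400 nM
compound 2 `O=C(CCl)Nc1ccc(Cn2nc(-c3ccc(Oc4ccccc4)cc3)cc2C(=O)O)cc1` – 1500 nM

Compound 1 holds the lower of the two numbers recorded in a functional assay on Z-138 cells (Homo sapiens) for inhibition, read by luminescence and CellTiter-Glo, with a stated time of 72 h; a lower number here means a stronger inhibitor, a higher number a weaker inhibitor. Among the compounds with values here, its only measured neighbour is compound 2, reached by carboxy in place of hydroxymethyl on an aromatic carbon, a change that gave a 3.8-fold higher number from compound 1 to compound 2 (0.57 log units; beyond the scatter). That is the whole of the measured record around this core.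

Compound 3 `C=CC(=O)Nc1ccc(Cn2nc(-c3ccc(Oc4ccccc4)cc3)cc2CO)cc1` keeps the hydroxymethyl of compound 1 and instead alters the amide end: vinyl in place of chloromethyl on a carbonyl carbon. Within the data shown here, none of the measured steps touches this position; the step from compound 1 to compound 2 concerns the group on the aromatic carbon and so says nothing direct about the carbonyl substituent. The expectation for compound 3 therefore rests on compound 1 alone, with wide uncertainty. A change in this assay beyond the scatter cannot be ruled out in either direction, and the estimate is centred close to compound 1, leaning slightly toward a higher number: compound 3 is expected at 600 nM, in the range 150 nM to 2500 nM, which amounts to an expected 1.5-fold higher number from compound 1 to compound 3 (0.18 log units; within the scatter).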

Compound 3, half-maximal inhibitory concentration: 6800 nM
Beside the measured number, compound 3's estimate is 11-fold (1.05 log units) below it; the whole stated range lies below it.
By their numbers in this assay, from the lowest: compound 1; then compound 2; then compound 3.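

In this assay the substituent on the carbonyl carbon proves to be a sensitive position: vinyl in place of chloromethyl gave a 17-fold higher number from compound 1 to compound 3 (1.23 log units; beyond the scatter) while the rest of the molecule stayed the same. Within the data shown here, the leaving and entering groups have the same heavy-atom count, so this large step does not come with any change in that count, and it exceeds the only earlier step, a 3.8-fold higher number from compound 1 to compound 2 (0.57 log units; beyond the scatter) on the aromatic carbon. Nothing available here bears on the reason for this step.

The compounds shown leave open whether the higher number reflects the arrival of vinyl or the departure of chloromethyl; a bromomethyl group, a propenyl group or a saturated ethyl group on the same carbonyl carbon would help to separate these two readings. Also open, going by these compounds, is how the vinyl group would read with a carboxy group in place of hydroxymethyl on the aromatic carbon, which would show whether the two changes act independently on the shared core.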